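The source may hold more compounds than are shown below. What is called first, only, known or untested is meant among the compounds shown, and "the series" means these compounds.

Measured so far:
Compound 1 `CCn1c(C(=O)NC(C)(C)CO)ccc1C(CC)(CC)c1ccc(OCS(=O)(=O)c2ccccc2)c(C)c1`: 9850 nM
Compound 2 `CCn1c(C(=O)N[C@@H](CO)CCCO)ccc1C(CC)(CC)c1ccc(OCS(=O)(=O)c2ccccc2)c(C)c1`: 13400 nM

Both compounds were tested in a functional assay on PC-3 cells (Homo sapiens) for antiproliferative activity, read by MTT assay, with a stated time of 24 h; on this read-out lower numbers stand for stronger inhibition and higher numbers for weaker inhibition. Compound 2, at 13400 nM, lies within the scatter of compound 1, at 9850 nM, so the two cannot be told apart on these numbers. Compound 3 `CCn1c(C(=O)N[C@H](C)C(=O)O)ccc1C(CC)(CC)c1ccc(OCS(=O)(=O)c2ccccc2)c(C)c1` keeps the shared core and changes only the group on an amide-type nitrogen: a group of 5 heavy atoms (3 carbon, 2 oxygen; no ring) in place of a group of 7 heavy atoms (5 carbon, 2 oxygen; no ring), on an amide-type nitrogen. Among the measured compounds shown here, the group that enters is 1-carboxyethyl, which no measured compound carries. For the measured compounds named here, only one measured step bears on this position, a 1.4-fold higher number from compound 1 to compound 2 (0.13 log units; within the scatter), and it stays within the scatter. On that single step, no change beyond the scatter is expected in this assay, and no direction can be firmly assigned. The estimated step is a 1.1-fold higher number from compound 2 to compound 3 (0.05 log units; within the scatter). For compound 3 the expected value is 15000 nM, with an estimated range of 6000 nM to 40000 nM.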

Compound 3, half-maximal inhibitory concentration: 20100 nM
The estimate for compound 3 lay 1.3-fold (0.13 log units) below the measured number; the measured number falls inside the stated range.
By their numbers in this assay, from the lowest: compounds 1, 2 and 3 (each within the scatter of the next, the first and the last beyond it).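

In this assay, among the compounds shown here, the step to 1-carboxyethyl on the amide-type nitrogen is a 1.5-fold higher number from compound 2 to compound 3 (0.18 log units; within the scatter) and so does not separate these two compounds, but measured against 1-(hydroxymethyl)-1-methylethyl the same group gives a 2.0-fold higher number from compound 1 to compound 3 (0.31 log units; beyond the scatter) and is the first step at this position to pass the scatter. The position is thus not wholly indifferent to the group it carries, although this step is modest and compound 2 cannot be told apart from either neighbour. No supporting data bear on why the numbers fall as they do.

The compounds shown leave open how an amine or a benzyl group on this nitrogen would read in this assay and whether the mirror-image form of 1-carboxyethyl would differ. They also leave open whether any group here can give a number clearly lower than that of compound 1.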